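Sulfonamide nitrogen substitution in the dichlorobenzamide series

This account rests on a few compounds, and the source may have more. Where it says the series, first, only, none or still open, it means among the compounds named here.

Of the compounds shown here, three have been measured in a functional assay on HEK293 cells for agonist activity at probable G-protein coupled receptor 27 (Homo sapiens), read by a luciferase reporter and beta-arrestin recruitment, with a stated time of 10 min; a lower number here means that less compound is needed, a higher number that more compound is needed for the effect. Compound 1 `O=C(Nc1ccc(S(=O)(=O)Nc2ccccc2)cc1)c1cc(F)c(Cl)cc1F` gives 141 nM. Compound 2 `CN(c1ccccc1)S(=O)(=O)c1ccc(NC(=O)c2ccc(Cl)cc2Cl)cc1` gives 2570 nM, the higher of the two numbers recorded, and its gap to compound 1 lies beyond the usual scatter. Compound 3 `O=C(Nc1ccccc1)c1ccc(NC(=O)c2ccc(Cl)cc2Cl)cc1` reaches only a limit of the assay, > 10000 nM, so no number is known for it; this is the limit of > 10000 nM in this assay, at which 1 of the 3 values shown sits.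

Compound 4 `O=C(Nc1ccc(S(=O)(=O)Nc2ccccc2Cl)cc1)c1ccc(Cl)cc1Cl` is not yet measured. It differs from compound 2 in one place: (2-chlorophenyl)amino in place of methyl(phenyl)amino on a sulfonyl sulfur. The acyl part and the remainder of the shared core stay as in compound 2, so the comparison isolates the sulfonamide nitrogen. Among the compounds with values here, no measured pair in this assay maps this exact change, so the expectation rests on the spread of the three values and on the unmethylated sulfonamide present in compound 1 with its 141 nM.

The step from compound 2 to compound 4 is expected to be a 6.4-fold lower number from compound 2 to compound 4 (0.81 log units; beyond the scatter), a move to a lower number beyond the scatter. For compound 4 in this assay the estimate is 400 nM, with a range from 100 nM to 1500 nM.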

Compound 4, half-maximal effective concentration: 1260 nM
The estimate for compound 4 lay 3.2-fold (0.50 log units) below the measured number, and the stated range covers the measured number.
By their numbers in this assay, from the lowest: compound 1; then compound 4; then compound 2. At a limit, above all of these: compound 3.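

In this assay, within the data shown here, (2-chlorophenyl)amino in place of methyl(phenyl)amino on a sulfonyl sulfur gives a 2.0-fold lower number from compound 2 to compound 4 (0.31 log units; beyond the scatter), the first direct reading at this position with the acyl part and the remainder of the shared core held constant. The step is modest, and the exchange removes the methyl and adds the chlorine at once, along with a hydrogen-bond donor, so the contribution of each cannot be separated. The compounds shown offer no measured basis for assigning a cause to this step.

From the compounds shown here alone, the separate effects of the methyl and the chlorine remain open, as does the effect of the chlorine's location on the ring. Also unresolved is how this position responds to other groups with the acyl part of compound 2, such as benzylamino or a methoxy-substituted phenylamino.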